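This account rests on a few compounds, and the source may have more. Where it says the series, first, only, none or still open, it means among the compounds named here.

Three compounds have been measured in a functional assay on TSGH 8302 cells (Homo sapiens) for cytotoxicity; a higher number here means a weaker inhibitor, a lower number a stronger inhibitor:

compound 1 `Cc1ccc(S(=O)(=O)N/C(=N\O)Nc2ccc(Cl)cc2)cc1` gives 46 ug/mL;
compound 2 `Cc1c(S(=O)(=O)N/C(=N\O)Nc2ccc(Cl)cc2)sc2ccc(Cl)cc12` gives 44 ug/mL;
compound 3 `Cc1ccc(S(=O)(=O)N/C(=N\O)Nc2ccc(Cl)c(Cl)c2)cc1` gives 67 ug/mL.

Compound 1 and compound 3 share a core and differ in a single place: chloro in place of hydrogen on an aromatic carbon. This change, chloro in place of hydrogen on an aromatic carbon, gave a 1.5-fold higher number from compound 1 to compound 3 (0.16 log units; within the scatter), a step that lies within the usual scatter of this assay, so the two values cannot be told apart with confidence. Compound 2 is built on a different core; the difference between the two cores is not broken down here. In this assay compound 2 and compound 1 give values that lie within the scatter of each other, and the same holds for compound 2 and compound 3.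

Compound 4 `Cc1c(S(=O)(=O)N/C(=N\O)Nc2ccc(Cl)c(Cl)c2)sc2ccc(Cl)cc12` has not yet been measured. It stands to compound 2 as compound 3 stands to compound 1: chloro in place of hydrogen on an aromatic carbon. The surroundings of the change read the same in both pairs, so it is the same change made on a second core. What can be expected for compound 4 rests on the measured step from compound 1 to compound 3 and on the value of compound 2, which is 44 ug/mL. Because the measured step was a 1.5-fold higher number from compound 1 to compound 3 (0.16 log units; within the scatter), a step of similar size is expected: a 1.4-fold higher number from compound 2 to compound 4 (0.13 log units; within the scatter). Compound 4 is therefore expected to give about 60 ug/mL in this assay, most likely between 35 ug/mL and 105 ug/mL.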

Compound 4, half-maximal inhibitory concentration: > 300 ug/mL
Compound 4: no number, only a limit; the forecaster's own chance of this, stated with the estimate: 5%; middle value at least 5.0-fold (0.69 log units) from the limit.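

On the core of compound 2, the change from 4-chlorophenyl to 3,4-dichlorophenyl gave an at least 6.8-fold higher number from compound 2 to compound 4 (0.83 log units; beyond the scatter), whereas the same change on the core of compound 1 stayed within the scatter, and the size of this step in this assay therefore did not carry over from one core to the other: the same change on two cores in this assay, a 1.5-fold higher number (0.16 log units; within the scatter) from compound 1 to compound 3 and an at least 6.8-fold higher number (0.83 log units; beyond the scatter) from compound 2 to compound 4, at least 4.6-fold (0.67 log units) apart, beyond the scatter of two such steps

In this assay compound 4 gives > 300 ug/mL, which is a limit of the assay and not a number, and the full size of its step stays unknown: the limit of > 300 ug/mL in this assay, at which 1 of the 4 values shown sits.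

Among these compounds, only one pair on each core stands behind this comparison: it shows that the same change can give steps of different size on these two cores, but it does not show why, and it gives no rule for a third core.

The compounds shown leave open whether the large step is particular to chloro or would also appear with fluoro, methyl or methoxy in the same place on the core of compound 2. They also leave open whether an amine or a carboxylic acid in that place would behave alike on the two cores or would again give steps that differ.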